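Anilide Swap on a Methoxyphenyl Core: What to Expect

The source may report more compounds than this note shows. Statements on the series, on what has been measured and on what is new or still open speak of the compounds shown alone.

Of the compounds shown here, three have been measured in a functional assay on QGY7701 cells (Homo sapiens) for cytotoxicity, read by MTT assay, with a stated time of 24 h; on this read-out higher numbers stand for weaker inhibition and lower numbers for stronger inhibition.
Compound 1 `C=CC1=C(C(=O)Nc2ccccc2OC)C(c2ccc(F)cc2)OC1` gives 52800 nM.
Compound 2 `C=CC1=C(C(=O)Nc2ccc(C)cc2)C(c2ccc(F)cc2)OC1` gives 59200 nM.
Compound 3 `C=CC1=C(C(=O)Nc2ccccc2OC)C(c2ccc(OC)cc2)OC1` gives > 100000 nM, which is a limit of the assay and not a number.

Compound 2 differs from compound 1 by 4-methylphenyl in place of 2-methoxyphenyl on an amide-type nitrogen. That change made a 1.1-fold higher number from compound 1 to compound 2 (0.05 log units; within the scatter). Compound 3 differs from compound 1 by methoxy in place of fluoro on an aromatic carbon, and that change made an at least 1.8-fold higher number from compound 1 to compound 3 (0.27 log units; that floor lies within the scatter). Compound 3 sits at the limit of > 100000 nM in this assay, at which 1 of the 3 values shown sits.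

Compound 4 `C=CC1=C(C(=O)Nc2ccc(C)cc2)C(c2ccc(OC)cc2)OC1` has not yet been measured in this assay. It differs from compound 3 by 4-methylphenyl in place of 2-methoxyphenyl on an amide-type nitrogen. The place is the same in both cases, an amide-type nitrogen whose other neighbours are a carbonyl carbon, so this is the same change as the one already seen, now made on the core of compound 3 rather than the core of compound 1. Because the earlier instance gave a 1.1-fold higher number from compound 1 to compound 2 (0.05 log units; within the scatter), the step from compound 3 to compound 4 is expected to be a step that the limit leaves unreadable from compound 3 to compound 4, a small one. Compound 4 is therefore estimated at 150000 nM, with a range from 80000 nM to 350000 nM, and will most likely again be reported only as a limit.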

Compound 4, half-maximal inhibitory concentration: > 100000 nM
Compound 4: a limit, no number (the forecaster's own chance of this, stated with the estimate: 80%); the middle value does not contradict the limit.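

In this assay compound 4 gives > 100000 nM, which is a limit of the assay and not a number. Compound 3 also sits at a limit, so the step from compound 3 to compound 4 cannot be read, and nothing here shows whether 4-methylphenyl in place of 2-methoxyphenyl behaves on the core of compound 3 as it did on the core of compound 1: the limit of > 100000 nM in this assay, at which 2 of the 4 values shown sit. The other change, methoxy in place of fluoro on an aromatic carbon, now appears as an at least 1.6-fold higher number from compound 2 to compound 4 (0.22 log units; that floor lies within the scatter), and set beside its earlier instance it reads: the same change on two cores in this assay, an at least 1.8-fold higher number (0.27 log units; that floor lies within the scatter) from compound 1 to compound 3 and an at least 1.6-fold higher number (0.22 log units; that floor lies within the scatter) from compound 2 to compound 4; the limit leaves it open whether they differ.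

The compounds shown leave open the actual numbers for compound 3 and compound 4, and with them whether either change has the same size on both cores. They also leave open what other groups would do on the amide-type nitrogen or in place of fluoro, such as a phenyl ring carrying a carboxylic acid, an amine, or a chlorine atom.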